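The source may report more compounds than this note shows. Statements on the series, on what has been measured and on what is new or still open speak of the compounds shown alone.

Measured compounds in a functional assay on MCF7 cells (Homo sapiens) for inhibition, read by MTT assay, with a stated time of 48 h; on this read-out higher numbers stand for weaker inhibition and lower numbers for stronger inhibition:
compound 1 `COc1cc(N(Cc2ccc(F)cc2)S(=O)(=O)c2ccc(C)cc2)cc(OC)c1OC`: 19200 nM
compound 2 `COc1cc(N(Cc2ccccc2)S(=O)(=O)c2ccc(C)cc2)cc(OC)c1OC`: 10200 nM
compound 3 `COc1cc(N(Cc2nc3ccccc3[nH]2)S(=O)(=O)c2ccccc2)cc(OC)c1OC`: 27300 nM

Compound 2 and compound 1 share a core and differ in one place only, (fluoro in place of hydrogen on an aromatic carbon). That change gave a 1.9-fold higher number from compound 2 to compound 1 (0.27 log units; within the scatter). Compound 3 carries a different core; the difference between the cores of compound 2 and compound 3 is not broken down here. In this assay compound 3 gives a number higher than that of compound 2, beyond the scatter, while its value and that of compound 1 lie within the scatter of each other.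

Compound 4 `COc1cc(N(Cc2nc3ccccc3[nH]2)S(=O)(=O)c2ccc(F)cc2)cc(OC)c1OC` has not yet been measured. It differs from compound 3 in fluoro in place of hydrogen on an aromatic carbon. The place matches that of the earlier pair, on an aromatic carbon of a six-membered aromatic ring of carbon only, para to a large group; read one bond further out, the earlier change is benzyl to 4-fluorobenzyl and the new one phenylsulfonyl to (4-fluorophenyl)sulfonyl, so the change is the same kind. The step from compound 3 to compound 4 is expected to be small, about a 1.3-fold higher number from compound 3 to compound 4 (0.11 log units; within the scatter), because a 1.9-fold higher number from compound 2 to compound 1 (0.27 log units; within the scatter) stayed within the scatter. Compound 4 is therefore estimated at 35000 nM in this assay, within a range from 15000 nM to 80000 nM.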

Compound 4, half-maximal inhibitory concentration: 9380 nM
The estimate for compound 4 lay 3.7-fold (0.57 log units) above the measured number; measured number outside the range, below it.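

In this assay, fluoro in place of hydrogen on an aromatic carbon gave a 2.9-fold lower number from compound 3 to compound 4 (0.46 log units; beyond the scatter), and set beside the same kind of change on the other core, this step does not match: the same change on two cores in this assay, a 1.9-fold higher number (0.27 log units; within the scatter) from compound 2 to compound 1 and a 2.9-fold lower number (0.46 log units; beyond the scatter) from compound 3 to compound 4, 5.5-fold (0.74 log units) apart, beyond the scatter of two such steps

Among these compounds, then, the step seen on one core was a poor guide to the step on the other. This rests on one pair per core, however, and the fluoro stands in a different setting in each pair, as 4-fluorobenzyl in compound 1 and as (4-fluorophenyl)sulfonyl in compound 4, so the compounds do not show whether the gap follows the core or the group that carries the fluoro, and they give no reason for it.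

The compounds shown leave open whether chloro or nitrile in the same place would give a step like that of fluoro on either core. They also leave open how the change would behave on the benzyl group of compound 2 if its methyl were replaced by hydrogen.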